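Changing the side chain of a potent orexin-2 antagonist

The compounds below may be only part of what the source reports. "The series", "measured", "known", "first", "only" and "open" are said of these compounds alone.

Measured compounds:
- compound 1, `N#Cc1cccc(C(=O)N2CCCCC2CCOc2ccc(Cl)c(Cl)c2)c1`: 631 nM
- compound 2, `O=C(c1ccccc1-c1ccccc1)N1CCCCC1CCOc1ccc(F)cc1`: 20 nM
- compound 3, `O=C(c1ccccc1-c1ccccc1)N1CCCC[C@H]1CCOc1ccc(F)cc1F`: 0.794 nM

Three compounds share a saturated ring carrying an aromatic amide, and each was tested in a functional assay on CHO cells for antagonist activity at Orexin receptor type 2 (Homo sapiens), read by FLIPR; a lower number here means a stronger inhibitor, a higher number a weaker inhibitor. Compound 1 gives 631 nM, compound 2 gives 20 nM, and compound 3 gives 0.794 nM. Compound 3 thus holds the lowest number of the three, well apart from compound 2 and even further from compound 1, both gaps lying beyond the usual scatter.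

The next compound, compound 4, `O=C(NC[C@@H]1CCCCN1C(=O)c1ccccc1-c1ccccc1)c1ccccc1`, departs from compound 3 in one place: benzamido in place of (2,4-difluorophenoxy)methyl on a saturated chain carbon bound to a saturated ring carbon. The aryl ether chain that all three measured compounds carry is thereby replaced by an amide-linked phenyl group. Among the measured compounds shown here, no measured pair reports this kind of exchange, so the direction and size of the step must be guessed. Because compound 3 sits at 0.794 nM, there is more room to rise than to fall, and a sizeable loss is the expected outcome, a 31-fold higher number from compound 3 to compound 4 (1.50 log units; beyond the scatter). Compound 4 is estimated at 25 nM, within a range of 3 nM to 250 nM.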

Compound 4, inhibition constant: 20 nM
Estimate against measurement, compound 4: 1.3-fold (0.10 log units) above; low and high end bracket the measured number.
By their numbers in this assay, from the lowest: compound 3; then compounds 2 and 4 (each within the scatter of the next); then compound 1.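

On this saturated chain carbon, benzamido in place of (2,4-difluorophenoxy)methyl brings a large loss in this assay (a 25-fold higher number from compound 3 to compound 4 (1.40 log units; beyond the scatter)). Even so, compound 4 still gives 20 nM and so shows that this position does not strictly need the aryl ether, since an amide-linked phenyl ring with a hydrogen-bond donor that the departing group lacks also leaves a working antagonist. Nothing available here accounts for the size of this loss.

Among the compounds shown here, the single step changes the link and removes both fluorines at once, so their separate shares of the loss remain unknown. On these data alone, whether a fluorinated benzamido group, or an amine linking the phenyl ring in place of the amide, would bring back what was lost also stays open.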